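Methyl on the benzamide ring: expectation for compound 3

The source may report more compounds than this note shows. Statements on the series, on what has been measured and on what is new or still open speak of the compounds shown alone.

Measured so far:
compound 1, `COc1cc2oc(-c3cccc(NC(=O)c4ccccc4)c3)cc(=O)c2c(OC)c1OC` — 12100 nM
compound 2, `COc1cc2oc(-c3cccc(NC(=O)c4ccccc4Br)c3)cc(=O)c2c(OC)c1OC` — 55000 nM

Two compounds of the series have numbers in a functional assay on MCF7 cells (Homo sapiens) for inhibition, read by MTT assay; on this read-out higher numbers stand for weaker inhibition of growth and lower numbers for stronger inhibition of growth. Compound 1 has the lowest number of the two; in this assay compound 1 gives 12100 nM, and compound 2 gives 55000 nM. Among the compounds with values here, the only step recorded is a 4.5-fold higher number from compound 1 to compound 2 (0.66 log units; beyond the scatter), a modest weakening of growth inhibition on bromination of the benzoyl ring.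

Compound 3, `COc1cc2oc(-c3cccc(NC(=O)c4ccc(C)cc4)c3)cc(=O)c2c(OC)c1OC`, is not yet measured. It differs from compound 1 in one place: methyl in place of hydrogen on an aromatic carbon. The group that enters is small and carries no donor or acceptor. Within the data shown here, the single known step concerns a different group at a different place on the same ring, so it bears on the present change only loosely; it shows that a substituent on the benzoyl ring can cost some potency, but says nothing about a methyl in the para position.

Among the measured compounds shown here, with no direct precedent, the expectation is a step within or near the scatter, leaning slightly toward a higher number: a 1.2-fold higher number from compound 1 to compound 3 (0.09 log units; within the scatter). Compound 3 is estimated at 15000 nM, with a range from 5000 nM to 45000 nM.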

Compound 3, concentration for 50% growth inhibition: 8320 nM
The estimate for compound 3 lay 1.8-fold (0.26 log units) above the measured number, within the range that was stated.
By their numbers in this assay, from the lowest: compounds 3 and 1 (each within the scatter of the next); then compound 2.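

In this assay, methyl in place of hydrogen on the benzoyl ring, para to a large group, leaves the number within the scatter (a 1.5-fold lower number from compound 1 to compound 3 (0.16 log units; within the scatter)), so this position accepts a methyl without a measurable change in growth inhibition. A substituent on this ring therefore does not always carry a cost: the loss seen with the 2-bromophenyl amide (a 4.5-fold higher number from compound 1 to compound 2 (0.66 log units; beyond the scatter)) does not appear with the 4-methylphenyl amide, and the two substituted compounds stand clearly apart (a 6.6-fold lower number from compound 2 to compound 3 (0.82 log units; beyond the scatter)), although that step changes both the group and its place on the ring. No measurement available here accounts for either the tolerance of the methyl or the loss with bromo.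

The compounds shown do not separate the identity of the group from its place, which 2-methylphenyl and 4-bromophenyl amides could do. Also open, going by these compounds, is whether the same position accepts something other than a methyl, such as a methoxy group, an amine, a carboxylic acid or a longer alkyl chain, and whether any of these would move the number beyond the scatter.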